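This account rests on a few compounds, and the source may have more. Where it says the series, first, only, none or still open, it means among the compounds named here.

Measured so far:
Compound 1, `Cc1cc(C(=O)NC(C)C)nn1Cc1cc(Cl)ccc1OCc1ccccc1`: 126 nM
Compound 2, `Cc1cc(NC(=O)OC(C)(C)C)nn1Cc1cc(Cl)ccc1OCc1ccccc1`: 25.1 nM

Going by the values given here, compound 2 holds the lower of the two numbers measured so far in an assay on CHO-K1 cells for displacement of a labelled ligand from prostaglandin E2 receptor EP1 subtype (Homo sapiens); on this read-out lower numbers stand for stronger inhibition and higher numbers for weaker inhibition. Among the compounds with values here, its only neighbour is compound 1, and the step of a 5.0-fold lower number from compound 1 to compound 2 (0.70 log units; beyond the scatter) sets it apart beyond the scatter, so compound 2 is the stronger of the two on this read-out.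

Compound 3, `CCOC(=O)Nc1cc(C)n(Cc2cc(Cl)ccc2OCc2ccccc2)n1`, differs from compound 2 by ethyl in place of tert-butyl on an oxygen next to a carbonyl group. Within the data shown here, the one measured step, a 5.0-fold lower number from compound 1 to compound 2 (0.70 log units; beyond the scatter), concerns an exchange of the whole group on the aromatic carbon, not a change of the alkyl on the oxygen next to the carbonyl group. Among the measured compounds shown here, it therefore tells little about the step from compound 2 to compound 3, and no second pair in this set carries the same change. With that lack of a guide, the expectation for compound 3 is a step of a 1.6-fold higher number from compound 2 to compound 3 (0.20 log units; within the scatter) that may not clear the scatter, with a slight lean toward a higher number than compound 2. Compound 3 is thus estimated at 40 nM in this assay, within a range of 15 nM to 120 nM.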

Compound 3, half-maximal inhibitory concentration: 79.4 nM
Compound 3: middle estimate off by 2.0-fold (0.30 log units), on the low side; measured number inside the range.
By their numbers in this assay, from the lowest: compound 2; then compounds 3 and 1 (each within the scatter of the next).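

In this assay the alkyl on the oxygen next to a carbonyl group proves to count on its own: ethyl in place of tert-butyl gives a 3.2-fold higher number from compound 2 to compound 3 (0.50 log units; beyond the scatter) and so moves the number beyond the scatter through a change that leaves the rest of the structure untouched. This also qualifies the earlier exchange on the aromatic carbon, since (ethoxycarbonyl)amino in place of isopropylcarbamoyl gives a 1.6-fold lower number from compound 1 to compound 3 (0.20 log units; within the scatter) and stays within the scatter, so among these three compounds only the group with tert-butyl on the oxygen stands apart from compound 1. No measurement at hand gives a reason for this difference between tert-butyl and ethyl.

With only two alkyl groups on that oxygen, the compounds shown do not tell whether the number follows the size of the chain or depends on the branched tert-butyl itself, which isopropyl, a longer chain such as n-butyl or a cyclopropyl ring in that place could test. They also leave open whether the oxygen itself is needed, as a tert-butylamino group or a neopentyl chain in place of tert-butoxy on the carbonyl would show.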